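Nitro to amino swap on two vinylsulfonamide cores

The compounds below may be only part of what the source reports. "The series", "measured", "known", "first", "only" and "open" are said of these compounds alone.

Measured compounds:
- compound 1, `COc1ccc(NS(=O)(=O)/C=C/c2c(F)c(F)c(F)c(F)c2F)cc1[N+](=O)[O-]`: 100000 nM
- compound 2, `COc1ccc(NS(=O)(=O)/C=C/c2c(F)c(F)c(F)c(F)c2F)cc1N`: 75000 nM
- compound 3, `COc1ccc(NS(=O)(=O)/C=C/c2c(OC)cc(OCCCC(=O)O)cc2OC)cc1[N+](=O)[O-]`: 100000 nM

All three numbers come from a functional assay on K562 cells (Homo sapiens) for cytotoxicity, read by trypan blue exclusion, with a stated time of 96 h; on this read-out higher numbers stand for weaker inhibition and lower numbers for stronger inhibition. Compound 1 and compound 2 share one core and differ in a single place: amino in place of nitro on an aromatic carbon. The step that goes with it is a 1.3-fold lower number from compound 1 to compound 2 (0.12 log units; within the scatter), so the two values are treated as one level.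

Compound 3 carries the other core; how the two cores differ is not broken down here. In this assay compound 3 gives 100000 nM, level with compound 1 at the digits shown.

Compound 4, `COc1ccc(NS(=O)(=O)/C=C/c2c(OC)cc(OCCCC(=O)O)cc2OC)cc1N`, is not yet measured. From compound 3 it differs by amino in place of nitro on an aromatic carbon. The place around it reads the same as for the first pair, so this is the same change. Within the data shown here, the only measured instance of it, a 1.3-fold lower number from compound 1 to compound 2 (0.12 log units; within the scatter), stays within the scatter. On that basis the step of a 1.2-fold lower number from compound 3 to compound 4 (0.07 log units; within the scatter) is expected to be small as well, and compound 4 is estimated at 85000 nM, with a range from 40000 nM to 150000 nM.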

Compound 4, half-maximal inhibitory concentration: 10000 nM
For compound 4 the middle estimate is 8.5-fold (0.93 log units) above the measured one; measured number outside the range, below it.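

In this assay, amino in place of nitro on the core of compound 3 gives a 10-fold lower number from compound 3 to compound 4 (1.00 log units; beyond the scatter), so the change does not carry over at one size from the core of compound 1. The two cores set the same change apart by more than the scatter of two such steps: the same change on two cores in this assay, a 1.3-fold lower number (0.12 log units; within the scatter) from compound 1 to compound 2 and a 10-fold lower number (1.00 log units; beyond the scatter) from compound 3 to compound 4, 7.5-fold (0.88 log units) apart, beyond the scatter of two such steps. This shows that, in these two pairs, the size of the step depends on the core into which the change is placed, but it does not show which part of the core matters, and two pairs give no rule for a third core.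

The compounds shown leave open whether the larger step stays with the carboxylic acid chain on the core of compound 3 or also appears with a methyl ester or a primary amide at the end of that chain. They also leave open whether an acetamide or a hydroxyl in place of the nitro would give a step like that of the amino on each core.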